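This account rests on a few compounds, and the source may have more. Where it says the series, first, only, none or still open, it means among the compounds named here.

Measured so far in a functional assay on CHO cells for agonist activity at Free fatty acid receptor 1 (Homo sapiens), read by FLIPR, tested at 100 nM; a higher number here means a stronger effect of the compound at the concentration tested, a lower number a weaker effect:
compound 1 `CC(Oc1ccccc1)C(=O)Nc1ccc(OCC(=O)O)c(F)c1`: 35.7%
compound 2 `Cc1ccc(C(C)C)cc1OC(C)C(=O)Nc1ccc(OCC(=O)O)c(F)c1`: 19.4%
compound 3 `Cc1ccc(OC(C)C(=O)Nc2ccc(OCC(=O)O)c(F)c2)cc1C`: 36.8%

Compound 3 holds the highest of the three numbers, yet compound 1 lies within the scatter of it; only compound 2, with a number lower beyond the scatter, is clearly separated. Among the measured compounds shown here, the single measured step, a number 1.1 percentage points higher from compound 1 to compound 3 (within the scatter), replaces phenyl with 3,4-dimethylphenyl and stays within the scatter.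

Compound 4 `Cc1ccc(C)c(OC(C)C(=O)Nc2ccc(OCC(=O)O)c(F)c2)c1` differs from compound 3 by 2,5-dimethylphenyl in place of 3,4-dimethylphenyl on an oxygen on a saturated carbon. For the measured compounds named here, no measured step rearranges methyl groups on this ring, so the step from compound 1 to compound 3 is the only one that bears on it, and it shows that two methyl groups on this phenyl barely moved the read-out. Going by the values given here, compound 2 carries a differently substituted ring and no step to it is computed, so its lower value is noted but not used. The expectation is therefore a step of no size beyond the scatter for compound 4, estimated at 33% with a range of 18% to 48%. This estimate means a number 3.8 percentage points lower from compound 3 to compound 4 (within the scatter) is expected.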

Compound 4, a percentage reported as activity, at one concentration (the size of the read-out at that concentration, not a potency) in the Free fatty acid receptor 1 assay: 18.7%
Compound 4: middle estimate off by 14.3 percentage points, on the high side, and the stated range covers the measured number.
By their numbers in the Free fatty acid receptor 1 assay, from the lowest: compounds 4 and 2 (each within the scatter of the next); then compounds 1 and 3 (each within the scatter of the next).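

In the Free fatty acid receptor 1 assay, the placement of the two methyl groups on this phenyl matters: although the 3,4-dimethylphenyl had given a number 1.1 percentage points higher from compound 1 to compound 3 (within the scatter) against plain phenyl, the change to 2,5-dimethylphenyl gives a number 18.1 percentage points lower from compound 3 to compound 4 (beyond the scatter) and, against the unsubstituted ring, a number 17 percentage points lower from compound 1 to compound 4 (beyond the scatter). On the 2,5-type pattern, the aromatic carbon that carries isopropyl in compound 2 tolerates methyl equally within this read-out, with a number 0.7 percentage points lower from compound 2 to compound 4 (within the scatter), so the two alkyl groups are not told apart here. Nothing available bears on the reason for this dependence on methyl placement. In a physicochemical assay for lipophilicity, using the shake flask method, at pH 7.4 (a higher number here means a more lipophilic compound, a lower number a more polar compound), compound 3 gives 0.33 and compound 4 gives "not determined" (no result reported) and the two therefore cannot be compared there.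

From the compounds shown here alone, whether the lower read-out belongs to one of the two methyl groups of the 2,5-dimethylphenyl or to the pair stays open. So does how a phenyl carrying chloro or methoxy in place of these methyl groups would read in the Free fatty acid receptor 1 assay.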